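A few compounds are considered here, and "the series" means these few. Any claim that something is new, unique, unknown or untested is made for them only; others in the source may bear on it.

Compound 1 (`CCOc1nc(N)nc2c1ncn2[C@@H]1O[C@H](CO)[C@@H](O)[C@@]1(C)O`) is the starting point of this account. In an ADME assay on Huh-7 cells (Homo sapiens) for cytotoxicity (on this read-out higher numbers stand for lower toxicity in this test and lower numbers for higher toxicity in this test), compound 1 gives > 100000 nM, which is a limit of the assay and not a number. Compound 2 (`CNc1nc(N)nc2c1ncn2[C@@H]1O[C@H](CO)[C@@H](O)[C@@]1(C)O`) also reaches only a limit, with > 100000 nM. The next compound to be tested is compound 3 (`CSc1nc(N)nc2c1ncn2[C@@H]1O[C@H](CO)[C@@H](O)[C@@]1(C)O`), where methylsulfanyl takes the place of ethoxy on an aromatic carbon: methylsulfanyl in place of ethoxy on an aromatic carbon. Among the compounds with values here, the one measured step that bears on this change is a step that the two limits leave unreadable from compound 1 to compound 2, which also replaces the ethoxy group of compound 1 at the same place. That step has no readable size, so it offers no measured effect to carry over. Within the data shown here, the only guide is the limit of > 100000 nM in this assay, at which 2 of the 2 values shown sit. On that basis, no step beyond the usual scatter is expected in this assay, and no direction can be assigned. The expected change is a number no higher from compound 1 to compound 3 (the limit leaves the size open). Compound 3 will most likely be reported as a limit again. If a number is obtained for compound 3, the estimate is 100000 nM, with an expected range from 45000 nM to 200000 nM.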

Compound 3, half-maximal cytotoxic concentration: > 100000 nM
Compound 3: a limit, no number; the forecaster's own chance of this, stated with the estimate: 80%; the middle value sits exactly at the limit.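

Compound 3 also ends at a limit and not a number in this assay, so the steps among compound 1, compound 2 and compound 3 cannot be read. The compounds shown leave open whether methylsulfanyl, methylamino and ethoxy differ at all on this read-out, as all that can be stated is a shared ceiling: the limit of > 100000 nM in this assay, at which 3 of the 3 values shown sit.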